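The source may report more compounds than this note shows. Statements on the series, on what has been measured and on what is new or still open speak of the compounds shown alone.

Measured compounds in a functional assay on RPMI-8226 cells (Homo sapiens) for cytotoxicity, read by sulforhodamine B assay, with a stated time of 48 h, tested at 10 uM; a lower number here means a stronger effect, a higher number a weaker effect of the compound at the concentration tested:
- compound 1, `COc1ccc(-c2cc(/C=C/C(=O)c3ccc(N)cc3)[nH]n2)cc1`: -35%
- compound 2, `COc1ccc(-c2cc(/C=C/C(=O)c3ccc(N)cc3)[nH]n2)cc1OC`: -20%
- compound 3, `COc1cc(C(=O)/C=C/c2cc(-c3cc(OC)c(OC)c(OC)c3)n[nH]2)cc(OC)c1OC`: -38%

Compound 1 and compound 2 share a core and differ in one place: hydrogen in place of methoxy on an aromatic carbon. The step between them in this assay is a number 15 percentage points lower from compound 2 to compound 1 (beyond the scatter). Compound 3 carries a different core; the difference between the core of compound 3 and the core of compound 2 is not broken down here. Compared with the other two, compound 3 gives the lowest number of the three, near compound 1 and further from compound 2.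

Compound 4, `COc1ccc(-c2cc(/C=C/C(=O)c3cc(OC)c(OC)c(OC)c3)[nH]n2)cc1OC`, remains to be measured. It is reached from compound 3 by hydrogen in place of methoxy on an aromatic carbon. This is the same kind of change as from compound 2 to compound 1, the same group leaving and the same hydrogen entering on an aromatic carbon of a six-membered aromatic ring of carbon only; the surroundings are not identical, since in compound 3 the place is also meta to a methoxy group, whereas in compound 2 it is ortho to a methoxy group and meta to a large group only.

Within the data shown here, only one measured instance of this change exists, so the expectation rests on that single step. The step from compound 3 to compound 4 is expected to be a number 12 percentage points lower from compound 3 to compound 4 (beyond the scatter), beside the earlier one, because compound 2 to compound 1 gave a number 15 percentage points lower from compound 2 to compound 1 (beyond the scatter) and the starting point of compound 3 is already low. For compound 4 the estimated value in this assay is -50%, with the expected range from -68% to -30%.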

Compound 4, a percentage reported as activity, at one concentration (the size of the read-out at that concentration, not a potency): -38%
Compound 4: middle estimate off by 12 percentage points, on the low side; measured number inside the range.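

In this assay, among these compounds, hydrogen in place of methoxy on an aromatic carbon now reads no change at the digits printed from compound 3 to compound 4 (within the scatter), so on the core of compound 3 the change gives no step that can be told from the scatter. Set beside the earlier step, this shows that the change does not carry over at a constant size from one core to the other in this series: the same change on two cores in this assay, a number 15 percentage points lower (beyond the scatter) from compound 2 to compound 1 and no change at the digits printed (within the scatter) from compound 3 to compound 4, 15 percentage points apart, beyond the scatter of two such steps With only two instances, and a read-out taken at one concentration rather than a potency, the data do not show which difference between the cores goes with the difference between the steps, nor how the change would behave on a third core.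

The compounds shown leave open what a hydroxyl group, a fluorine atom or a longer chain such as ethoxy would give in place of the methoxy on that aromatic carbon, on either core. They also leave open how each core would read with no methoxy at all on that ring, and whether a step would appear there in this assay.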